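Amine variation on the shared core: cytotoxicity notes

The source may report more compounds than this note shows. Statements on the series, on what has been measured and on what is new or still open speak of the compounds shown alone.

Compound 1 `COc1cc2cc(C#N)ccc2c(OC)c1Oc1cc(NC(C)(C)C)nc(Nc2ccc(C#N)cc2)n1` carries a (tert-butyl)amino group on the shared core. In an ADME assay on MT4 cells (Homo sapiens) for cytotoxicity, read by MTT assay, with a stated time of 5 days (on this read-out lower numbers stand for higher toxicity in this test and higher numbers for lower toxicity in this test), compound 1 gives only a limit, > 125000 nM. Compound 2 `COc1cc2cc(C#N)ccc2c(OC)c1Oc1cc(NCC(C)(C)C)nc(Nc2ccc(C#N)cc2)n1` has neopentyl in place of tert-butyl on a nitrogen on an aromatic ring, and in this assay compound 2 likewise returns a limit, > 125000 nM. Compound 3 `COc1cc2cc(C#N)ccc2c(OC)c1Oc1cc(NC2CC2)nc(Nc2ccc(C#N)cc2)n1` has cyclopropyl in place of tert-butyl on a nitrogen on an aromatic ring, and in this assay compound 3 gives a limit as well, > 125000 nM. For the measured compounds named here, the steps are thus a step that the two limits leave unreadable from compound 1 to compound 2, a step that the two limits leave unreadable from compound 1 to compound 3 and a step that the two limits leave unreadable from compound 2 to compound 3, and the sole evidence is the limit of > 125000 nM in this assay, at which 3 of the 3 values shown sit.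

Compound 4 `COc1cc2cc(C#N)ccc2c(OC)c1Oc1cc(N2CCC(O)C2)nc(Nc2ccc(C#N)cc2)n1` differs from compound 1 as follows: 3-hydroxypyrrolidin-1-yl in place of (tert-butyl)amino on an aromatic carbon. Going by the values given here, none of the measured steps introduces a ring on the nitrogen, so the three unreadable steps bear on compound 4 only by showing that every member of the series sits at the limit. The expected step is a number no higher from compound 1 to compound 4 (the limit leaves the size open), none beyond the scatter. Compound 4 is therefore estimated at 125000 nM, within 60000 nM to 250000 nM, and is most likely to be reported again as a limit.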

Compound 4, half-maximal cytotoxic concentration: > 125000 nM
Compound 4: only a limit was reported (the forecaster's own chance of this, stated with the estimate: 80%); the middle value sits exactly at the limit.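

No new step can be read between compound 4 and compound 1, compound 2 or compound 3, since all four give only a limit in this assay: the limit of > 125000 nM in this assay, at which 4 of the 4 values shown sit. The compounds shown leave open whether any amine group on the shared core changes the read-out in this assay, and by how much.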